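Moving the Methyl: Cytotoxicity Expected for Compound 4

The source may report more compounds than this note shows. Statements on the series, on what has been measured and on what is new or still open speak of the compounds shown alone.

Of the compounds shown here, three sharing one core have been measured in an ADME assay on HEK-293T cells (Homo sapiens) for cytotoxicity, read by MTT assay, with a stated time of 24 h; a lower number here means that less compound is tolerated, a higher number that more compound is tolerated. Compound 1 `Cc1ccc(C(=O)n2c(-c3cn(-c4ccccc4)nc3-c3ccc(C(F)(F)F)cc3)nc3ccccc32)cc1` gives 169000 nM. Compound 2 `Cc1ccc(C(=O)n2c(-c3cn(-c4ccccc4)nc3-c3ccc(F)cc3)nc3ccccc32)cc1` gives 178000 nM, and compound 3 `Cc1ccc(C(=O)n2c(-c3cn(-c4ccccc4)nc3-c3ccc(C(F)(F)F)cc3)nc3ccccc32)cn1` gives 153000 nM. The two steps between them are small: a 1.1-fold higher number from compound 1 to compound 2 (0.02 log units; within the scatter) and a 1.1-fold lower number from compound 1 to compound 3 (0.04 log units; within the scatter). Compound 2 thus stands with its neighbours, its number lying within the usual scatter of both compound 1 and compound 3, so no ordering among the three can be claimed.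

Compound 4 `Cc1cccc(C(=O)n2c(-c3cn(-c4ccccc4)nc3-c3ccc(F)cc3)nc3ccccc32)c1` has not yet been measured in this assay. It differs from compound 2 in one place: 3-methylphenyl in place of 4-methylphenyl on a carbonyl carbon.

For the measured compounds named here, no measured step moves a methyl on this aromatic ring, so none bears directly on the change. The nearest analogue is the change at the same carbonyl carbon from compound 1 to compound 3, which stayed within the scatter, and the change at the other aromatic carbon from compound 1 to compound 2 did likewise. On that basis the step from compound 2 to compound 4 is expected to be a 1.0-fold lower number from compound 2 to compound 4 (0.01 log units; within the scatter), no change beyond the scatter. Compound 4 is therefore estimated at 175000 nM, within a range from 90000 nM to 350000 nM.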

Compound 4, half-maximal cytotoxic concentration: 148000 nM
Compound 4: the middle estimate sits 1.2-fold (0.07 log units) above what was measured, and the stated range covers the measured number.
By their numbers in this assay, from the lowest: compounds 4, 3, 1 and 2 (each within the scatter of the next).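

Moving the methyl, with 3-methylphenyl in place of 4-methylphenyl on a carbonyl carbon whose other neighbour is an aromatic nitrogen, gives a 1.2-fold lower number from compound 2 to compound 4 (0.08 log units; within the scatter) in this assay. This is the only step shown that keeps the atoms the same and alters only how they are joined, so it adds a test of the methyl's placement to the earlier exchange at this carbonyl carbon, a 1.1-fold lower number from compound 1 to compound 3 (0.04 log units; within the scatter), and neither step goes beyond the scatter. No measurement shown offers an explanation for how these numbers fall.

All four compounds still carry a methyl on the aromatic ring attached to the carbonyl carbon, so the compounds shown leave open whether an amine, a carboxylic acid or a longer alkyl chain at that place would give a number beyond the scatter of compound 2. They also leave open whether the closeness of these numbers would hold for a group other than trifluoromethyl or fluoro at the other aromatic carbon, such as a methoxy group or a nitrile.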